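From furan-2-yl to 1-benzofuran-2-yl at the assay limit

The compounds below may be only part of what the source reports. "The series", "measured", "known", "first", "only" and "open" are said of these compounds alone.

Compound 1 `Cc1nc(N)c2c(-c3cc4ccccc4o3)cn([C@@H]3O[C@H](CO)[C@@H](O)[C@H]3O)c2n1` gives > 20000 nM as a limit
Compound 2 `Nc1nc2c(c(-c3ccco3)cn2[C@@H]2O[C@H](CO)[C@@H](O)[C@H]2O)c(=O)[nH]1` gives > 20000 nM as a limit

Both readings come from a functional assay on HL-60 cells (Homo sapiens) for antiproliferative activity, read by XTT assay, with a stated time of 72 h (on this read-out lower numbers stand for stronger inhibition and higher numbers for weaker inhibition), and neither is an exact number. Compound 2 gives only a limit (> 20000 nM). The other compound shares that position, so the measured set offers no number by which to rank them (the limit of > 20000 nM in this assay, at which 2 of the 2 values shown sit).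

Compound 3 `Nc1nc2c(c(-c3cc4ccccc4o3)cn2[C@@H]2O[C@H](CO)[C@@H](O)[C@H]2O)c(=O)[nH]1` has not yet been measured. It differs from compound 2 in one place, on an aromatic carbon of a five-membered aromatic ring with 1 nitrogen, where 1-benzofuran-2-yl stands in place of furan-2-yl (1-benzofuran-2-yl in place of furan-2-yl on an aromatic carbon). Among the compounds with values here, no measured pair gives the size of such a change.

The expected change a number no higher from compound 2 to compound 3 (the limit leaves the size open) is none beyond the scatter, and a further limit is the likeliest report. That expectation rests on compound 2, whose reading is a limit (> 20000 nM). In this assay compound 3 is expected at an estimated 20000 nM (range 7000 nM to 40000 nM).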

Compound 3, half-maximal inhibitory concentration: > 20000 nM
Compound 3: only a limit was reported; the forecaster's own chance of this, stated with the estimate: 80%; the middle value lies on the limit itself.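

In this assay compound 3 gives > 20000 nM, which is a limit and not a number. Within the data shown here, compound 2 also stands at a limit, so no step from compound 2 to compound 3 can be read: the limit of > 20000 nM in this assay, at which 3 of the 3 values shown sit.

The compounds shown leave open how 1-benzofuran-2-yl in place of furan-2-yl changes activity, and which group on this core would give an exact reading.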